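Solubility of a Quinoline Series: Estimating Compound 4

The compounds below may be only part of what the source reports. "The series", "measured", "known", "first", "only" and "open" are said of these compounds alone.

Measured compounds:
compound 1, `CC(C)(C)c1ccc(Oc2ccc3c(NCCCNCc4ccco4)ccnc3c2)cc1`, 14500 nM
compound 2, `COc1cccc(CNCCCNc2ccnc3cc(-c4ccccc4)ccc23)c1O`, 32000 nM
compound 3, `COc1cccc(CNCCCNc2ccnc3cc(Cc4ccc(C#N)cc4)ccc23)c1O`, 4200 nM

Of the compounds shown here, three have been measured in a physicochemical assay for solubility, with a stated time of 18 h, at pH 7.4; a higher number here means a more soluble compound, a lower number a less soluble compound. Compound 3 stands lowest of the three; its nearest neighbour is compound 1, and compound 2 lies furthest above it. Within the data shown here, the only step between two measured compounds that differ in one place is the one from compound 2 to compound 3, a 7.6-fold lower number from compound 2 to compound 3 (0.88 log units; beyond the scatter).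

Compound 4, `COc1cccc(CNCCCNc2ccnc3cc(Oc4ccc(C(C)(C)C)cc4)ccc23)c1O`, differs from compound 3 as follows: 4-(tert-butyl)phenoxy in place of 4-cyanobenzyl on an aromatic carbon. Among the measured compounds shown here, no measured pair shows exactly this exchange. The step of a 7.6-fold lower number from compound 2 to compound 3 (0.88 log units; beyond the scatter) shows that the 4-cyanobenzyl group is associated with the lowest solubility in the set, so removing it could move the number upward. Compound 1, which carries the same 4-(tert-butyl)phenoxy group on its core, gives 14500 nM in this assay, a number well above compound 3. Taken together, the expectation for compound 4 is a modest rise, estimated as a 2.6-fold higher number from compound 3 to compound 4 (0.42 log units; beyond the scatter). Compound 4 is therefore estimated at 11000 nM, with a range from 3500 nM to 35000 nM.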

Compound 4, solubility: 14500 nM
Compound 4: middle estimate off by 1.3-fold (0.12 log units), on the low side, and the stated range covers the measured number.
By their numbers in this assay, from the lowest: compound 3; then compounds 1 and 4 (each within the scatter of the next); then compound 2.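

In this assay, the position on the aromatic carbon of the shared core responds to more than one exchange: 4-(tert-butyl)phenoxy in place of 4-cyanobenzyl gives a 3.5-fold higher number from compound 3 to compound 4 (0.54 log units; beyond the scatter), while the same group in place of phenyl gives a 2.2-fold lower number from compound 2 to compound 4 (0.34 log units; beyond the scatter). With the side chain held constant, the three groups at this place now form an order, each step beyond the scatter: phenyl gives the highest number, 4-(tert-butyl)phenoxy the middle one and 4-cyanobenzyl the lowest. At the other end of the molecule, with 4-(tert-butyl)phenoxy on the core, 2-hydroxy-3-methoxyphenyl in place of furan-2-yl on the saturated chain carbon bound to an amine nitrogen gives no change at the digits printed from compound 1 to compound 4 (within the scatter), so this single pair shows that exchange leaving the number within the scatter.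

Nothing shown here accounts for the order of the three groups at the aromatic carbon. Still open, going by these compounds, are how an amine or a carboxylic acid on this aromatic carbon would read, and whether the furan-2-yl exchange would again fall within the scatter with phenyl or 4-cyanobenzyl on the core.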